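This account rests on a few compounds, and the source may have more. Where it says the series, first, only, none or still open, it means among the compounds named here.

Working notes on the series in a functional assay on SK-MEL-28 cells (Homo sapiens) for inhibition, read by sulforhodamine B assay, with a stated time of 48 h; a lower number here means a stronger inhibitor of growth, a higher number a weaker inhibitor of growth. Compound 1 `COc1ccc2[nH]c(-c3ccccc3)c(C=C(C#N)C#N)c2c1` gives 4400 nM; compound 2 `COc1ccc(-c2[nH]c3ccc(OC)cc3c2C=C(C#N)C#N)cc1` gives 1700 nM; compound 3 `COc1ccc2[nH]c(-c3ccccc3)c(/C=C(\C#N)S(=O)(=O)c3ccccc3)c2c1` gives 6100 nM. Compound 1 and compound 2 differ in one place, (hydrogen in place of methoxy on an aromatic carbon), and the step is a 2.6-fold higher number from compound 2 to compound 1 (0.41 log units; beyond the scatter). Compound 3 stands highest of the three numbers; against compound 1 the gap is within the scatter, against compound 2 it is beyond it. The difference between the core of compound 3 and the core of compound 2 is not broken down here.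

Compound 4 `N#C/C(=C\c1c(-c2ccccc2)[nH]c2ccccc12)S(=O)(=O)c1ccccc1` is not yet measured in this assay. It differs from compound 3 by hydrogen in place of methoxy on an aromatic carbon. Among the compounds with values here, this is the same kind of change as the one from compound 2 to compound 1, not the same: there the carbon is para to a large group, here it sits on a six-membered aromatic ring of carbon only that is part of a fused system of two rings, meta to a fused ring and para to a fused ring. Because the measured step is a 2.6-fold higher number from compound 2 to compound 1 (0.41 log units; beyond the scatter), a step of the same direction is expected, a 1.8-fold higher number from compound 3 to compound 4 (0.26 log units; within the scatter), with wide uncertainty since the place differs. Compound 4 is estimated at 11000 nM in this assay, with a range from 4000 nM to 30000 nM.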

Compound 4, concentration for 50% growth inhibition: 8300 nM
Beside the measured number, compound 4's estimate is 1.3-fold (0.12 log units) above it; the range from low to high includes it.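

In this assay, hydrogen in place of methoxy gives a 1.4-fold higher number from compound 3 to compound 4 (0.13 log units; within the scatter), so on this core the change cannot be told apart from repeat scatter. Set beside the earlier step, the result gives no sign that the change behaves differently on the two cores: the same change on two cores in this assay, a 2.6-fold higher number (0.41 log units; beyond the scatter) from compound 2 to compound 1 and a 1.4-fold higher number (0.13 log units; within the scatter) from compound 3 to compound 4, 1.9-fold (0.28 log units) apart, within the scatter of two such steps
Within the data shown here, this does not show that the change carries over with a fixed size, since only two cores are compared, the methoxy leaves a different place on each, and one of the two steps is itself within the scatter.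

The compounds shown leave open what other groups on the aromatic carbon of the fused system would do, such as fluorine, an amine or a longer alkoxy chain. They also leave open whether hydrogen in place of methoxy would read the same way on cores beyond these two.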